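The source may report more compounds than this note shows. Statements on the series, on what has been measured and on what is new or still open speak of the compounds shown alone.

Measured so far in a physicochemical assay for lipophilicity, read by HPLC; a higher number here means a more lipophilic compound, a lower number a more polar compound:
compound 1 `CCn1c(-c2cnc(C)nc2)nc2c(N[C@H]3CCN(C(=O)c4cocn4)C3)ncnc21`, 0.6
compound 2 `CCC(=O)N1CC[C@H](Oc2ncnc3c2nc(-c2cnc(C)nc2)n3CC)C1`, 0.8
compound 3 `CCn1c(-c2ccc(C(F)(F)F)nc2)nc2c(O[C@H]3CCN(C(=O)c4cocn4)C3)ncnc21`, 2

Compound 3 stands highest of these three numbers; compound 2 is the nearest to it and compound 1 the furthest, and both sit lower by margins beyond the usual scatter of the measurement. Compound 4 `CCn1c(-c2ccc(C(F)(F)F)nc2)nc2c(O[C@H]3CCN(C(=O)[C@H]4C[C@@H](OC)C4)C3)ncnc21` differs from compound 3 in one place: 3-methoxycyclobutyl in place of 1,3-oxazol-4-yl on a carbonyl carbon. A 1,3-oxazol-4-yl group leaves the carbonyl carbon and a 3-methoxycyclobutyl group enters there. For the measured compounds named here, no measured pair shows this exchange, so its size must be estimated. In this assay the step of a number 0.70 log units higher from compound 3 to compound 4 (beyond the scatter) is expected to be an increase beyond the scatter. Compound 4 is therefore estimated at 2.7, within a range from 2.2 to 3.3.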

Compound 4, distribution coefficient: 2.2
Compound 4: the middle estimate sits 0.50 log units above what was measured; low and high end bracket the measured number.
By their numbers in this assay, from the lowest: compounds 1 and 2 (each within the scatter of the next); then compounds 3 and 4 (each within the scatter of the next).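

On a carbonyl carbon whose other neighbour is an amide-type nitrogen in a ring, putting 3-methoxycyclobutyl in place of 1,3-oxazol-4-yl gives a step of a number 0.20 log units higher from compound 3 to compound 4 (within the scatter) in this assay. For the compounds shown here, this is the first comparison here between compounds differing in one place, and the two groups cannot be told apart in this measurement, although one is a five-membered aromatic ring and the other a four-membered non-aromatic carbon ring. No measurement at hand offers an explanation for this.

On these data alone, it remains open how a phenyl ring or a carboxylic acid at this position would read in this assay. A single pair also cannot show whether this exchange would read the same on other compounds.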